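This account rests on a few compounds, and the source may have more. Where it says the series, first, only, none or still open, it means among the compounds named here.

Working notes on the series. In an assay on cells for binding affinity to Cyclin-C/Cyclin-dependent kinase 19 (Homo sapiens), read by LanthaScreen (on this read-out higher numbers stand for weaker inhibition and lower numbers for stronger inhibition), compound 1 `Cn1cnc2ccc(-c3cnc4[nH]ccc4c3N3CCC4(CCNC4=O)CC3)cc21` gives 11 nM, compound 2 `O=C1NCCC12CCN(c1c(-c3ccc4ncsc4c3)cnc3[nH]ccc13)CC2` gives 80 nM and compound 3 `Cn1cnc2cc(-c3cnc4[nH]ccc4c3N3CCC4(CCNC4=O)CC3)ccc21` gives 50 nM; compound 3 thus stands second highest of the three numbers. Compound 4 `O=C1NCCC12CCN(c1c(-c3ccn4ccnc4c3)cnc3[nH]ccc13)CC2` carries a group of 9 heavy atoms (7 carbon, 2 nitrogen; one five-membered aromatic ring with 2 hetero atoms, one six-membered aromatic ring with 1 hetero atom) in place of a group of 10 heavy atoms (8 carbon, 2 nitrogen; one five-membered aromatic ring with 2 hetero atoms, one six-membered aromatic ring of carbon only), on an aromatic carbon. Among the compounds with values here, the measured steps that bear on such an aryl swap are a 4.5-fold higher number from compound 1 to compound 3 (0.66 log units; beyond the scatter), a 7.3-fold higher number from compound 1 to compound 2 (0.86 log units; beyond the scatter) and a 1.6-fold lower number from compound 2 to compound 3 (0.20 log units; within the scatter), so swaps at this position have ranged from no clear change to a modest shift, with no step pointing one way in particular. A step of about a 1.2-fold higher number from compound 3 to compound 4 (0.08 log units; within the scatter) in this assay is therefore expected, with either direction possible. Compound 4 is estimated at 60 nM, within a range of 20 nM to 200 nM.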

Compound 4, half-maximal inhibitory concentration: 68 nM
Compound 4: the middle estimate sits 1.1-fold (0.05 log units) below what was measured; measured number inside the range.
By their numbers in this assay, from the lowest: compound 1; then compounds 3, 4 and 2 (each within the scatter of the next).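

In this assay, the new group, with a hetero atom in its six-membered aromatic ring, gives a 1.4-fold higher number from compound 3 to compound 4 (0.13 log units; within the scatter) and a 1.2-fold lower number from compound 2 to compound 4 (0.07 log units; within the scatter), so a third aryl group joins the same cluster. Against the 1-methyl-1H-benzimidazol-6-yl group the step is a 6.2-fold higher number from compound 1 to compound 4 (0.79 log units; beyond the scatter), which leaves that group as the only one of the four beyond the scatter of all the others. No measured evidence accounts for this separation. Still open, from the compounds shown here alone, is whether a carboxylic acid or an aminomethyl group on the 1-methyl-1H-benzimidazol-6-yl ring would retain the number of compound 1, 11 nM.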